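The source may report more compounds than this note shows. Statements on the series, on what has been measured and on what is new or still open speak of the compounds shown alone.

Compound 3 `CC1CCC(=NNc2c(Cl)cccc2Cl)c2ncc(C(=O)O)c(=O)n21` carries a 2,6-dichlorophenyl group. In a functional assay on the whole organism with Rattus norvegicus as the target (on this read-out higher numbers stand for an effect only at larger amounts of compound and lower numbers for an effect already at smaller amounts), compound 3 reaches only the limit of the assay, > 100 umol/kg. Compound 1 `CC1CCC(=NNc2ccccc2)c2ncc(C(=O)O)c(=O)n21` has a plain phenyl in that place and gives 1.2 umol/kg in this assay. Compound 2 `CC1CCC(=NNc2cc(Cl)cc(Cl)c2)c2ncc(C(=O)O)c(=O)n21` with 3,5-dichlorophenyl also reaches only the limit, > 100 umol/kg. Both dichloro variants thus share the limit (the limit of > 100 umol/kg in this assay, at which 2 of the 3 values shown sit). The measured steps are an at least 83-fold higher number from compound 1 to compound 3 (1.92 log units; beyond the scatter) and an at least 83-fold higher number from compound 1 to compound 2 (1.92 log units; beyond the scatter), while a step that the two limits leave unreadable from compound 2 to compound 3. Compound 4 `Cc1cccc(Cl)c1NN=C1CCC(C)n2c1ncc(C(=O)O)c2=O` differs from compound 3 by methyl in place of chloro on an aromatic carbon, read one bond further out as 2,6-dichlorophenyl to 2-chloro-6-methylphenyl. Since one chloro remains and compound 3 sits at the limit, no change beyond the scatter is expected: a number no higher from compound 3 to compound 4 (the limit leaves the size open). Compound 4 is therefore estimated at 100 umol/kg, between 25 umol/kg and 400 umol/kg.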

Compound 4, dose for 50% inhibition: > 100 umol/kg
Compound 4: no number, only a limit (the forecaster's own chance of this, stated with the estimate: 65%); the middle value lies on the limit itself.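

In this assay compound 4 also gives only a limit, > 100 umol/kg. The loss therefore does not depend on having two chloro groups: with methyl in place of one chloro, the phenyl of compound 1 is still not matched, with an at least 83-fold higher number from compound 1 to compound 4 (1.92 log units; beyond the scatter). The steps among compound 2, compound 3 and compound 4 cannot be read, so methyl and chloro cannot be told apart here: the limit of > 100 umol/kg in this assay, at which 3 of the 4 values shown sit.

Going by these compounds, whether a phenyl carrying only one fluoro or one methoxy group keeps the effect of compound 1 stays open. On these data alone, the true numbers behind the limits also remain unknown.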